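Methoxy for chloro on the aryl ring of compound 2

A few compounds are considered here, and "the series" means these few. Any claim that something is new, unique, unknown or untested is made for them only; others in the source may bear on it.

Two analogues sharing the same core have been measured in a functional assay on PC-3 cells (Homo sapiens) for cytotoxicity, read by sulforhodamine B assay, with a stated time of 48 h; on this read-out lower numbers stand for stronger inhibition of growth and higher numbers for weaker inhibition of growth. Compound 1 `CC1=C(C(=O)Nc2ccc(F)c(Cl)c2)C(c2cccc(Oc3ccccc3)c2)NC(=O)N1` gives 22400 nM in this assay. Compound 2 `CC1=C(C(=O)Nc2ccc(F)c(Cl)c2)C(c2cccc(Cl)c2)NC(=S)N1` gives 25100 nM in this assay. Among the measured compounds shown here, the two numbers lie within the scatter of each other, so neither compound can be ranked against the other; both sit at weak growth inhibition, and no step between measured compounds is available to guide the next change.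

Compound 3 `COc1cccc(C2NC(=S)NC(C)=C2C(=O)Nc2ccc(F)c(Cl)c2)c1` differs from compound 2 in one place: methoxy in place of chloro on an aromatic carbon. Cut one bond further out, the change reads 3-chlorophenyl to 3-methoxyphenyl.

With no measured step of this kind in the series, the step from compound 2 to compound 3 is expected to be small, without clear direction, and most likely within the scatter, as a 1.1-fold higher number from compound 2 to compound 3 (0.05 log units; within the scatter). Compound 3 is estimated at 28000 nM in this assay, within a range of 12000 nM to 70000 nM.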

Compound 3, concentration for 50% growth inhibition: 23400 nM
Beside the measured number, compound 3's estimate is 1.2-fold (0.08 log units) above it, within the range that was stated.
By their numbers in this assay, from the lowest: compounds 1, 3 and 2 (each within the scatter of the next).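

Methoxy in place of chloro on this aromatic carbon, meta to a large group, gives a 1.1-fold lower number from compound 2 to compound 3 (0.03 log units; within the scatter) in this assay, the only step in the series so far that can be read. At this place, 3-chlorophenyl and 3-methoxyphenyl are therefore not separated by this read-out, even though methoxy counts a hydrogen-bond acceptor and chloro does not. No measurement at hand bears on the reason for this result.

Open, as far as these compounds go, is whether an amine or a carboxylic acid on the same aromatic carbon would give a number beyond the scatter from compound 2. Also open, from the compounds shown here alone, is whether methoxy in place of chloro would read the same with a carbonyl in place of the thiocarbonyl of the shared core.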